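The source may report more compounds than this note shows. Statements on the series, on what has been measured and on what is new or still open speak of the compounds shown alone.

Measured in a functional assay on A-431 cells (Homo sapiens) for inhibition, read by sulforhodamine B assay, with a stated time of 2 days; a lower number here means a stronger inhibitor of growth, a higher number a weaker inhibitor of growth:
- compound 1 `CC1=C(C(=O)Nc2ccc(C)cc2)C(c2ccc(O)cc2O)NC(NCc2ccccc2)=N1`: 42700 nM
- compound 2 `CC1=C(C(=O)Nc2cccc([N+](=O)[O-])c2)C(c2ccc(O)cc2O)NC(NCc2ccccc2)=N1`: 35600 nM
- compound 3 `CC1=C(C(=O)Nc2cccc([N+](=O)[O-])c2)C(c2ccc(O)cc2O)NC(Nc2ccc(S(=O)(=O)Nc3cc(C)on3)cc2)=N1`: 2940 nM

Compound 2 lies within the scatter of compound 1, and compound 3 stands well below both. Compound 4 `CC1=C(C(=O)Nc2cccc([N+](=O)[O-])c2)C(c2ccc(O)cc2O)NC(NN)=N1` departs from compound 2 by one change, amino in place of benzyl on an amine nitrogen.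

For the measured compounds named here, no measured step covers this change. The only one, a 1.2-fold lower number from compound 1 to compound 2 (0.08 log units; within the scatter), concerns 3-nitrophenyl in place of 4-methylphenyl on an amide-type nitrogen, so it says little about the amine nitrogen. Compound 3, with a different group on that nitrogen, gives 2940 nM, whereas compound 2 gives 35600 nM. That single pair shows that the numbers can differ widely, but it sets no direction for amino. No step beyond the scatter is therefore expected in this assay, although the uncertainty is wide.

The expected change is a 1.2-fold lower number from compound 2 to compound 4 (0.07 log units; within the scatter). For compound 4 the estimated value is 30000 nM, with an expected range of 9000 nM to 90000 nM.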

Compound 4, concentration for 50% growth inhibition: 24300 nM
For compound 4 the middle estimate is 1.2-fold (0.09 log units) above the measured one, within the range that was stated.
By their numbers in this assay, from the lowest: compound 3; then compounds 4, 2 and 1 (each within the scatter of the next).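

In this assay, the result gives a 1.5-fold lower number from compound 2 to compound 4 (0.17 log units; within the scatter), so benzyl and amino on the amine nitrogen cannot be told apart here, although amino brings no ring and fewer heavy atoms. For the compounds shown here, at this position, then, the six-membered aromatic ring of benzyl can be lost without a step beyond the scatter, while compound 3, at 2940 nM, remains the only compound with a much lower number. Nothing measured here bears on why these numbers fall as they do.

The compounds shown leave open which part of the group on compound 3 goes with its lower number. A plain phenyl or a sulfonamide-free pyridine on that amine nitrogen, with the 3-nitrophenyl amide kept, would begin to separate those parts.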